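The source may report more compounds than this note shows. Statements on the series, on what has been measured and on what is new or still open speak of the compounds shown alone.

Compound 1, with the structure `CCCC[C@]1(CC)CS(=O)(=O)c2cc(O)ccc2[C@@H](c2ccccc2)[C@H]1O`, is the starting point of this comparison. In an assay on cells for inhibition of ileal sodium/bile acid cotransporter (Homo sapiens) (on this read-out higher numbers stand for weaker inhibition and lower numbers for stronger inhibition), compound 1 gives 90 nM, the lowest of the two numbers measured here. Compound 3, with the structure `CCCC1(CCC)CS(=O)(=O)c2ccc(N)cc2[C@@H](c2ccccc2)[C@H]1O`, gives 230 nM in this assay, a higher number than compound 1 by a step beyond the usual scatter. Compound 2, with the structure `CC1(C)CS(=O)(=O)c2ccc(N)cc2[C@@H](c2ccccc2)[C@H]1O`, reaches only the limit of this assay, > 50000 nM, so no number is known for it; this is the situation described by the limit of > 50000 nM in this assay, at which 1 of the 3 values shown sits. Compound 4, with the structure `CCCC[C@]1(CC)CS(=O)(=O)c2cc(OC)ccc2[C@@H](c2ccccc2)[C@H]1O`, has not yet been measured. It differs from compound 1 in one place: methyl in place of hydrogen on an oxygen on an aromatic ring. For the measured compounds named here, no measured pair shows the effect of this change, so the expectation rests on compound 1 alone. The step from compound 1 to compound 4 in this assay is expected to be small, a 2.2-fold higher number from compound 1 to compound 4 (0.35 log units; beyond the scatter), most likely towards a somewhat higher number. Compound 4 is therefore estimated at 200 nM, within a range from 60 nM to 800 nM.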

Compound 4, half-maximal inhibitory concentration: 120 nM
The estimate for compound 4 lay 1.7-fold (0.22 log units) above the measured number, within the range that was stated.
By their numbers in this assay, from the lowest: compounds 1, 4 and 3 (each within the scatter of the next, the first and the last beyond it). At a limit, above all of these: compound 2.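

In this assay, methyl in place of hydrogen on the oxygen on the aromatic ring leaves compound 4 level with compound 1 (a 1.3-fold higher number from compound 1 to compound 4 (0.12 log units; within the scatter)). On the core of compound 1, then, the hydrogen of the hydroxy group is not needed for a number in this range. The earlier compounds shown here could not show this, as none of them carried anything other than hydrogen on this oxygen. Nothing measured here explains why the change makes so little difference.

As far as these compounds go, it remains open whether this tolerance extends to a larger group on the same oxygen, such as ethoxy, benzyloxy or a longer chain. A carboxylic acid at this place on the ring is equally untested among the compounds shown.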